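The source may report more compounds than this note shows. Statements on the series, on what has been measured and on what is new or still open speak of the compounds shown alone.

Working notes on the series. Three measured compounds share one core: compound 1 `c1ccc(CSc2nnc(-c3ccc4c(c3)OCCO4)n2-c2ccccc2)cc1`, compound 2 `Clc1ccccc1CSc1nnc(-c2ccc3c(c2)OCCO3)n1-c1ccccc1` and compound 3 `Cc1ccc(CSc2nnc(-c3ccc4c(c3)OCCO4)n2-c2ccccc2)cc1`. In a functional assay on HeLa cells (Homo sapiens) for antiproliferative activity, read by MTT assay, with a stated time of 24 h (on this read-out lower numbers stand for stronger inhibition and higher numbers for weaker inhibition), compound 1 gives 32800 nM, compound 2 gives 29000 nM and compound 3 gives 49700 nM. Compound 3 sits at the upper end of these three numbers, but the gaps around it are small: a 1.5-fold higher number from compound 1 to compound 3 (0.18 log units; within the scatter) and a 1.7-fold higher number from compound 2 to compound 3 (0.23 log units; within the scatter), so the three compounds are not separated in this assay. The step of a 1.1-fold lower number from compound 1 to compound 2 (0.05 log units; within the scatter) likewise stays within the scatter.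

Compound 4 `Fc1ccc(CSc2nnc(-c3ccc4c(c3)OCCO4)n2-c2ccccc2)c(F)c1` is not yet measured. It differs from compound 3 by 2,4-difluorophenyl in place of 4-methylphenyl on a saturated chain carbon bound to a sulfur. The measured steps bear on it only loosely: both a chloro and a methyl on the phenyl of this benzyl group, and the exchange of one substituted phenyl for another, left this assay unchanged beyond the scatter. Within the data shown here, no measured step involves fluorine. On that basis no step beyond the scatter is expected from compound 3 to compound 4, and the estimate is a 1.3-fold lower number from compound 3 to compound 4 (0.12 log units; within the scatter). Compound 4 is therefore expected to give about 38000 nM in this assay, within a range from 15000 nM to 90000 nM.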

Compound 4, half-maximal inhibitory concentration: 18600 nM
Beside the measured number, compound 4's estimate is 2.0-fold (0.31 log units) above it; low and high end bracket the measured number.
By their numbers in this assay, from the lowest: compounds 4, 2, 1 and 3 (each within the scatter of the next, the first and the last beyond it).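

Among these compounds, at the saturated chain carbon bound to a sulfur, the exchange of 4-methylphenyl for 2,4-difluorophenyl gives the only step that lies beyond the scatter in this assay (a 2.7-fold lower number from compound 3 to compound 4 (0.43 log units; beyond the scatter)). The separation holds against compound 3 alone: the same group stays within the scatter of the 2-chlorophenyl and the unsubstituted phenyl (a 1.6-fold lower number from compound 2 to compound 4 (0.19 log units; within the scatter); a 1.8-fold lower number from compound 1 to compound 4 (0.25 log units; within the scatter)), so this position has so far shown only a modest range. Nothing at hand explains the step from 4-methylphenyl to 2,4-difluorophenyl.

The compounds shown leave open whether a phenyl carrying a single fluorine would separate from compound 3 as compound 4 does. They also leave open how this position responds to a group of a different kind, such as an amine or a carboxylic acid on the phenyl, or to a longer chain ahead of it.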